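Swapping Anilino for 4-Nitrophenyl on a Shared Core

This account rests on a few compounds, and the source may have more. Where it says the series, first, only, none or still open, it means among the compounds named here.

Of the compounds shown here, three with one shared core have been tested in a functional assay on the whole organism (strain albino) for inhibition, with Rattus norvegicus as the target, read by paw edema, with a stated time of 1 h, at a dose of 20 mmol/kg by the intraperitoneal route; on this read-out lower numbers stand for less inhibition and higher numbers for more inhibition at the one dose given (going by the name of the read-out). Compound 1, `N#CC1=C(/N=C/Nc2ccc([N+](=O)[O-])cc2)N(c2ccccc2)C(=O)N2CCCCC(N3CCCC3)C12`, gives 32.1% in this assay. Compound 2, `N#CC1=C(NCN2CCCCC2)N(c2ccccc2)C(=O)N2CCCCC(N3CCCC3)C12`, gives 29.7% in this assay. Compound 3, `N#CC1=C(/N=C/Nc2ccccc2)N(c2ccccc2)C(=O)N2CCCCC(N3CCCC3)C12`, gives 35.2% in this assay, the highest of the three numbers, though its gaps to the other two fall within the scatter, so no ordering among them can be claimed.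

The new compound 4 is `N#CC1=C(/N=C/c2ccc([N+](=O)[O-])cc2)N(c2ccccc2)C(=O)N2CCCCC(N3CCCC3)C12`. Its difference from compound 3 is 4-nitrophenyl in place of anilino on a carbon with a double bond to nitrogen.

Going by the values given here, two measured steps bear on this change. The nitro group is lost in the step of a number 3.1 percentage points higher from compound 1 to compound 3 (within the scatter), a step within the scatter. The whole group on the double-bonded ring carbon is exchanged in the step of a number 2.4 percentage points lower from compound 1 to compound 2 (within the scatter) and again in the step of a number 5.5 percentage points higher from compound 2 to compound 3 (within the scatter), both within the scatter. Every change made so far at this part of the core has left the read-out within the scatter, and there is no measurement of a 4-nitrophenyl joined directly to the carbon with a double bond to nitrogen.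

Compound 4 is therefore estimated to give 32%, with a range from 22% to 42%. The step this estimate means, a number 3.2 percentage points lower from compound 3 to compound 4 (within the scatter), is expected to stay within the scatter.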

Compound 4, a percentage reported as inhibition, in the whole organism at one dose (the size of the read-out at that dose, not a potency): 66%
Estimate against measurement, compound 4: 34 percentage points below, outside the stated range (above it).
By their numbers in this assay, from the lowest: compounds 2, 1 and 3 (each within the scatter of the next); then compound 4.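

In this assay, going by these compounds alone, the carbon with a double bond to nitrogen proves to be a place on the shared core where a change can move the number beyond the scatter, which no earlier step did: putting 4-nitrophenyl in place of anilino gives a number 30.8 percentage points higher from compound 3 to compound 4 (beyond the scatter), and the wider exchange of the whole group on the double-bonded ring carbon gives a number 36.3 percentage points higher from compound 2 to compound 4 (beyond the scatter). The nitro group is present on both sides of one step, where 4-nitrophenyl in place of (4-nitrophenyl)amino gives a number 33.9 percentage points higher from compound 1 to compound 4 (beyond the scatter), so the large rise appears only with the amino nitrogen gone from this carbon, whereas losing the nitro group alone had stayed within the scatter. No measurement at hand gives a reason for this jump.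

What the compounds shown leave open is whether the nitro group has any share in the high number once the aromatic ring sits directly on this carbon. A plain phenyl there, or a phenyl carrying an amine or a carboxylic acid in place of the nitro group, would separate the two parts of the change.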